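The compounds below may be only part of what the source reports. "The series", "measured", "known", "first", "only" and "open" are said of these compounds alone.

Measured so far:
- compound 1 `Cc1nn(-c2ncnc3nc[nH]c23)c2c1C(OCC(=O)c1ccc(F)cc1)CC(=O)N2`: 973 nM in a functional assay on HEK293 cells for agonist activity at G-protein coupled receptor 39 (Homo sapiens), read by scintillation proximity assay and inositol phosphate accumulation, with a stated time of 75 min; a higher number here means that more compound is needed for the effect, a lower number that less compound is needed
- compound 2 `Cc1nn(-c2ncnc3nc[nH]c23)c2c1C(C(=O)NCc1ccc(F)cc1)CC(=O)N2`: 1220 nM in this assay
- compound 3 `Cc1cc(C)nc(-n2nc(C)c3c2NC(=O)CC3c2ccc(F)cc2F)n1`: in this assay only a limit, > 10000 nM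

Compound 1 holds the lowest of the two numbers shown, and compound 2 sits within the scatter of it, so no order between them can be read. Compound 4 `Cc1nn(-c2ncnc3nc[nH]c23)c2c1C(OCc1cc(F)cc3c1OCOC3)CC(=O)N2` is not yet measured; it differs from compound 1 by a group of 11 heavy atoms (8 carbon, 2 oxygen, 1 fluorine; one six-membered non-aromatic ring with 2 hetero atoms, one six-membered aromatic ring of carbon only) in place of a group of 9 heavy atoms (7 carbon, 1 oxygen, 1 fluorine; one six-membered aromatic ring of carbon only), on a saturated chain carbon bound to an oxygen on a saturated carbon. No measured step in this series bears on such a change, and the two numbers shown leave the size of it open. The expectation for compound 4 in this assay is a step of a 1.3-fold higher number from compound 1 to compound 4 (0.13 log units; within the scatter), not beyond the scatter in either direction. Compound 4 is estimated at 1300 nM, between 400 nM and 4500 nM.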

Compound 4, half-maximal effective concentration: 30 nM
Compound 4: middle estimate off by 43-fold (1.64 log units), on the high side; the whole stated range lies above it.
By their numbers in this assay, from the lowest: compound 4; then compounds 1 and 2 (each within the scatter of the next). At a limit, above all of these: compound 3.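

In this assay, going by these compounds alone, the group on the saturated chain carbon bound to an oxygen on a saturated carbon proves a strong lever on the number: the change gives a 32-fold lower number from compound 1 to compound 4 (1.51 log units; beyond the scatter) and no earlier step showed this. The carbonyl leaves and the non-aromatic ring enters in the same change, so their shares in the step cannot be separated. No measurement shown bears on the reason for the step.

Going by these compounds, whether an unsubstituted benzyl group would hold the low number remains open. An amine or a carboxylic acid at this place is equally untested here.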